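Swapping fluoro for chloro on a metabolic stability series

A few compounds are considered here, and "the series" means these few. Any claim that something is new, unique, unknown or untested is made for them only; others in the source may bear on it.

- compound 1 `FC(F)(F)c1ccccc1-c1ccc2[nH]c(C3=NOC4(CCCCC4)C3)nc2c1` gives 100% in an ADME assay on microsomes from liver (Homo sapiens) for metabolic stability, with a stated time of 10 min; a lower number here means that less of the compound is left, a higher number that more of the compound is left
- compound 2 `Fc1cc(-c2ccccc2C(F)(F)F)cc2nc(C3=NOC4(CCCCC4)C3)[nH]c12` gives 46% in this assay

Among the measured compounds shown here, compound 2 holds the lower of the two numbers so far. Compound 3 `FC(F)(F)c1ccccc1-c1cc(Cl)c2[nH]c(C3=NOC4(CCCCC4)C3)nc2c1` has not been measured, and the change leading to it is chloro in place of fluoro on an aromatic carbon (chloro in place of fluoro on an aromatic carbon, ortho to a fused ring). For the measured compounds named here, one measured step bears on this: a number 54 percentage points lower from compound 1 to compound 2 (beyond the scatter) (fluoro in place of hydrogen on an aromatic carbon). That step is large, but it replaces hydrogen rather than fluoro, so it is only a loose guide. No step beyond the scatter is therefore expected in this assay, and the estimated step is a number 4 percentage points lower from compound 2 to compound 3 (within the scatter) (with wide uncertainty). The expected value for compound 3 is 42% (estimated range 18% to 70%).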

Compound 3, percent of the compound remaining: 92%
Compound 3: middle estimate off by 50 percentage points, on the low side; measured number outside the range, above it.
By their numbers in this assay, from the lowest: compound 2; then compounds 3 and 1 (each within the scatter of the next).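

In this assay, the position ortho to a fused ring turns out to depend strongly on which halogen sits there: chloro in place of fluoro gives a number 46 percentage points higher from compound 2 to compound 3 (beyond the scatter). Chloro in place of hydrogen gives a number 8 percentage points lower from compound 1 to compound 3 (within the scatter), so the drop seen with fluoro does not extend to every halogen at this position. Nothing available explains why fluoro and chloro differ so sharply here.

From the compounds shown here alone, whether a methyl or methoxy group at this position would behave like chloro or like fluoro remains open.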